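Aryl swap from compound 2 to compound 3: working notes

The compounds below may be only part of what the source reports. "The series", "measured", "known", "first", "only" and "open" are said of these compounds alone.

Going by the values given here, two members carry a result entry in a functional assay on MCF7 cells (Homo sapiens) for inhibition, read by MTT assay, with a stated time of 72 h (on this read-out higher numbers stand for weaker inhibition and lower numbers for stronger inhibition), but only one of them a number. Compound 1 `COc1ccc(Cn2cc(CSC(=S)N3CCNCC3)nn2)cc1` has no result recorded in this assay: for compound 1 the entry reads "not determined" (no result reported). Among the compounds with values here, compound 2 `COc1ccc(Cn2cc(CSC(=S)N3CCN(C(=O)OC(C)(C)C)CC3)nn2)cc1` is therefore the only compound with a measured value, and in this assay compound 2 gives 4960 nM; nothing else in the set can be set beside it, so it stands alone rather than high or low.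

Compound 3 `CC(C)(C)OC(=O)N1CCN(C(=S)SCc2cn(Cc3ccccc3Cl)nn2)CC1` is not yet measured. It differs from compound 2 in one place: 2-chlorophenyl in place of 4-methoxyphenyl on a saturated chain carbon bound to an aromatic nitrogen. Within the data shown here, no step between two measured compounds exists here, so there is no calibration for what a change at this position does to the read-out. Among the measured compounds shown here, on the single number available, the expectation for the step in this assay is modest, with no clear direction, and most likely within the scatter of repeated measurements; the step from compound 2 to compound 3 is estimated as a 1.1-fold lower number from compound 2 to compound 3 (0.04 log units; within the scatter). For compound 3 in this assay the expected value is 4500 nM, with a plausible range from 1500 nM to 14000 nM.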

Compound 3, half-maximal inhibitory concentration: 6090 nM
Compound 3: the middle estimate sits 1.4-fold (0.13 log units) below what was measured, and the stated range covers the measured number.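

Going by these compounds alone, this is the first measured step at this position: in this assay the swap of 2-chlorophenyl for 4-methoxyphenyl on a saturated chain carbon bound to an aromatic nitrogen gives a 1.2-fold higher number from compound 2 to compound 3 (0.09 log units; within the scatter). The position therefore tolerates the exchange of 4-methoxybenzyl for 2-chlorobenzyl, with its different ring substituent and its loss of the hydrogen-bond acceptor counted for the leaving group, without a read-out that can be told apart from repeat measurements. No measured property of either group is available to account for this result.

The two aryl groups shown do not define how far this tolerance extends, and one step cannot separate the contribution of the substituent's identity from that of its location on the ring, so no trend can be drawn from compound 2 and compound 3 alone. Going by these compounds, whether the read-out stays as flat with an amine or a carboxylic acid on the phenyl ring, or with a longer chain in place of the benzyl carbon, remains open.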